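Swapping the aryl amine substituent on a quinoxaline sulfone

This account rests on a few compounds, and the source may have more. Where it says the series, first, only, none or still open, it means among the compounds named here.

Measured compounds:
- compound 1, `Nc1cccc(Nc2nc3ccccc3nc2S(=O)(=O)c2ccccc2)c1`: 2150 nM
- compound 2, `COc1cc(Nc2nc3ccccc3nc2S(=O)(=O)c2ccc(C)cc2)cc(OC)c1`: 2940 nM

Both compounds were tested in a functional assay on PC-3 cells (Homo sapiens) for cytotoxicity, read by MTT assay, with a stated time of 72 h; on this read-out lower numbers stand for stronger inhibition and higher numbers for weaker inhibition. Compound 2 has the highest of the two numbers, and its nearest neighbour is compound 1 with a lower number, but the gap between them falls within the scatter of repeated measurements, so the two compounds cannot be told apart on these data.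

Compound 3, `Cc1ccc(S(=O)(=O)c2nc3ccccc3nc2Nc2cccc(N)c2)cc1`, has not yet been measured in this assay. It differs from compound 2 in one place: 3-aminophenyl in place of 3,5-dimethoxyphenyl on a nitrogen on an aromatic ring. The same 3-aminophenyl group is carried by compound 1, which gives 2150 nM in this assay, so the entering group is already known in this series at a similar level of inhibition.

Among the measured compounds shown here, no measured pair isolates this single change, so the expectation rests on what the two values show. The step from compound 2 to compound 3 is expected to be small, towards a slightly lower number, and not beyond the scatter: a 1.3-fold lower number from compound 2 to compound 3 (0.11 log units; within the scatter). Compound 3 is therefore expected to give about 2300 nM, with a range from 1100 nM to 4800 nM.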

Compound 3, half-maximal inhibitory concentration: 2000 nM
Beside the measured number, compound 3's estimate is 1.2-fold (0.06 log units) above it, within the range that was stated.
By their numbers in this assay, from the lowest: compounds 3, 1 and 2 (each within the scatter of the next).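

In this assay, among the compounds shown here, the step of a 1.5-fold lower number from compound 2 to compound 3 (0.17 log units; within the scatter) gives the first direct reading of this change on a nitrogen on an aromatic ring: with 3-aminophenyl in place of 3,5-dimethoxyphenyl, the two compounds cannot be told apart, even though the two groups differ in size and in their counts of hydrogen-bond donors and acceptors. The step of a 1.1-fold lower number from compound 1 to compound 3 (0.03 log units; within the scatter) adds a second single-place reading, and methyl in place of hydrogen on an aromatic carbon also stays within the usual scatter, so neither change separates the compounds in this small set. No other measurement is available that could give a cause for either result.

The compounds shown leave open whether a group of a different kind on that nitrogen, such as a phenyl ring carrying a carboxylic acid or an open butyl chain in place of the ring, would separate clearly from these three in this assay and so show how much this position matters. Going by these compounds, it also remains open whether a chlorine or a methoxy group in place of the methyl would give a step beyond the scatter.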